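Aryl replacement on the pyrazole acid series: compound 4

The compounds below may be only part of what the source reports. "The series", "measured", "known", "first", "only" and "open" are said of these compounds alone.

Measured compounds:
compound 1 `Cc1nn(-c2nc(-c3ccc(Cl)c(Cl)c3)c(SC(C)C)s2)c(C(=O)O)c1-c1cnn(C)c1`: 6800 nM
compound 2 `COc1cncc(-c2c(C)nn(-c3nc(-c4ccc(Cl)c(Cl)c4)c(SC(C)C)s3)c2C(=O)O)c1`: 21000 nM
compound 3 `Cc1nn(-c2nc(-c3ccc(Cl)c(Cl)c3)c(SC(C)C)s2)c(C(=O)O)c1-c1cccc(C(F)(F)F)c1`: 22000 nM

In a functional assay on BJAB cells (Homo sapiens) for antiproliferative activity, with a stated time of 4 days (a higher number here means that more compound is needed for the effect, a lower number that less compound is needed), compound 3 holds the highest of the three numbers. Its nearest neighbour is compound 2, which differs only within the scatter, so no order between the two can be stated; compound 1 is the furthest, with a 3.2-fold higher number from compound 1 to compound 3 (0.51 log units; beyond the scatter) separating them. Compound 4 `Cc1cc(-c2c(C)nn(-c3nc(-c4ccc(Cl)c(Cl)c4)c(SC(C)C)s3)c2C(=O)O)cc(C)n1` differs from compound 3 by 2,6-dimethylpyridin-4-yl in place of 3-(trifluoromethyl)phenyl on an aromatic carbon. Within the data shown here, two measured steps bear on this position. The step of a 3.1-fold higher number from compound 1 to compound 2 (0.49 log units; beyond the scatter) and the step of a 3.2-fold higher number from compound 1 to compound 3 (0.51 log units; beyond the scatter) both show that leaving the 1-methyl-1H-pyrazol-4-yl raises the number modestly, while a 1.0-fold higher number from compound 2 to compound 3 (0.02 log units; within the scatter) shows that exchanging one six-membered aryl for another leaves the number in place. A change from one six-membered ring to another with one ring nitrogen and one acceptor, as in compound 2, is thus expected to give no step beyond the scatter in this assay. Compound 4 is expected at 18000 nM, within 7000 nM to 50000 nM. The expected step is a 1.2-fold lower number from compound 3 to compound 4 (0.09 log units; within the scatter), within the scatter.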

Compound 4, half-maximal effective concentration: 580 nM
Beside the measured number, compound 4's estimate is 31-fold (1.49 log units) above it; measured number below the stated range.
By their numbers in this assay, from the lowest: compound 4; then compound 1; then compounds 2 and 3 (each within the scatter of the next).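

The position is not indifferent to the choice of six-membered aryl in this assay: the exchange of one such ring for another gave no step beyond the scatter (a 1.0-fold higher number from compound 2 to compound 3 (0.02 log units; within the scatter)), whereas 2,6-dimethylpyridin-4-yl gives large steps against both earlier six-membered groups (a 38-fold lower number from compound 3 to compound 4 (1.58 log units; beyond the scatter); a 36-fold lower number from compound 2 to compound 4 (1.56 log units; beyond the scatter)). The entering group also goes beyond the five-membered 1-methyl-1H-pyrazol-4-yl (a 12-fold lower number from compound 1 to compound 4 (1.07 log units; beyond the scatter)), so the five-membered ring no longer holds the lowest number at this position, and having left it need not raise the number. No measurement available here accounts for these steps.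

The compounds shown do not separate the contribution of the two methyl groups from that of the ring nitrogen. Unsubstituted pyridin-4-yl and a dimethylphenyl group at the same carbon would make that separation.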